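Amide Variation on a Shared Core: Expecting Compound 4

This account rests on a few compounds, and the source may have more. Where it says the series, first, only, none or still open, it means among the compounds named here.

Three amides built on one shared core have been tested in a functional assay on the whole organism (strain Wistar) for inhibition, with Rattus norvegicus as the target, read by paw edema, with stated times of 60 min and 6 h, at a dose of 100 mg/kg by the oral route; on this read-out lower numbers stand for less inhibition and higher numbers for more inhibition at the one dose given (going by the name of the read-out). Compound 1 `COc1cc2c(cc1OC)C(CC(=O)N(C)C)CC2` gives 33.3%. Compound 2 `CCCCCNC(=O)CC1CCc2cc(OC)c(OC)cc21` gives 35.2%. Compound 3 `COc1cc2c(cc1OC)C(CC(=O)NC1CCCC1)CC2` gives 40.7%. Compound 3 therefore holds the highest of the three numbers, yet its margin is slight: the step of a number 5.5 percentage points higher from compound 2 to compound 3 (within the scatter) and the step of a number 7.4 percentage points higher from compound 1 to compound 3 (within the scatter) both fall within the scatter, so the three compounds cannot be ranked against one another.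

The next compound, compound 4 `COc1cc2c(cc1OC)C(CC(=O)N1CCCCC1)CC2`, differs from compound 3 in a single place: piperidin-1-yl in place of cyclopentylamino on a carbonyl carbon. The measured steps that bear on this change are those that alter the group on the carbonyl carbon: a number 1.9 percentage points higher from compound 1 to compound 2 (within the scatter), a number 7.4 percentage points higher from compound 1 to compound 3 (within the scatter) and a number 5.5 percentage points higher from compound 2 to compound 3 (within the scatter). Every one of them stayed within the scatter, whether dimethylamino, pentylamino or cyclopentylamino stood there. Going by the values given here, no measured step has yet placed piperidin-1-yl on that carbon, so the data give no direct guide for it. On this basis no step beyond the scatter is expected in this assay in either direction, and compound 4 is expected to give 38%, within 26% to 50%. The expected step of a number 2.7 percentage points lower from compound 3 to compound 4 (within the scatter) is thus estimated to be essentially flat.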

Compound 4, a percentage reported as inhibition, in the whole organism at one dose (the size of the read-out at that dose, not a potency): 31.5%
For compound 4 the middle estimate is 6.5 percentage points above the measured one; the measured number falls inside the stated range.
By their numbers in this assay, from the lowest: compounds 4, 1, 2 and 3 (each within the scatter of the next).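

In this assay, going by these compounds alone, piperidin-1-yl is the only group among the four on the carbonyl carbon whose nitrogen sits inside a ring, and the steps of a number 9.2 percentage points lower from compound 3 to compound 4 (within the scatter) and a number 3.7 percentage points lower from compound 2 to compound 4 (within the scatter) and a number 1.8 percentage points lower from compound 1 to compound 4 (within the scatter) show that this group too stays within the scatter of the three earlier amides. The exchange for cyclopentylamino keeps the heavy-atom count and replaces a five-membered ring of carbon only, carrying a hydrogen-bond donor, with a six-membered ring holding one hetero atom and no donor, yet on this read-out that combined change cannot be told apart from the scatter. No accompanying measurement offers any explanation for these numbers.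

As far as these compounds go, what morpholin-4-yl, phenylamino or a free carboxylic acid on that carbonyl carbon would give remains open, as does whether any group there can produce a step beyond the scatter. Also open is how these four amides would compare at doses other than the single one shown, since one dose gives the size of the read-out and no potency.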